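The source may hold more compounds than are shown below. What is called first, only, known or untested is meant among the compounds shown, and "the series" means these compounds.

Of the compounds shown here, three that share one core have been tested in an assay on HEK293 cells with Neuronal acetylcholine receptor; alpha4/beta2 (Homo sapiens) as the target, read by FLIPR and calcium flux; a higher number here means a larger maximal response, a lower number a smaller maximal response. Compound 1 `COc1cc(N2CCCNCC2)cnc1Cl` gives 116% in this assay. Compound 2 `C=COc1cc(N2CCCNCC2)cnc1Br` gives 80% in this assay. Compound 3 `COc1cncc(N2CCCNCC2)c1` gives 66% in this assay, the lowest of the three numbers, and its gaps to compound 2 and to compound 1 both lie beyond the scatter. Going by the values given here, the only single-point step among the measured compounds is a number 50 percentage points lower from compound 1 to compound 3 (beyond the scatter), a large drop.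

Compound 4 `C=COc1cncc(N2CCCNCC2)c1` has not yet been measured. It differs from compound 3 in one place: vinyl in place of methyl on an oxygen on an aromatic ring. Among the compounds with values here, no measured step isolates this change: compound 1 and compound 2 differ in two places at once, so their two numbers cannot separate the methoxy-to-vinyloxy change from the halogen change. With no direct guide, the step from compound 3 to compound 4 is expected to be small, a number 6 percentage points lower from compound 3 to compound 4 (within the scatter), within or close to the scatter. For compound 4 the estimated maximal response in this assay is 60%, with a range from 40% to 85%.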

Compound 4, largest response reached (reported as efficacy), in percent of the reference or control that the assay uses: 61%
Beside the measured number, compound 4's estimate is 1 percentage points below it; the measured number falls inside the stated range.
By their numbers in this assay, from the lowest: compounds 4 and 3 (each within the scatter of the next); then compound 2; then compound 1.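

In this assay, vinyl in place of methyl on an oxygen on an aromatic ring gives a number 5 percentage points lower from compound 3 to compound 4 (within the scatter), so on this core without a halogen, the two groups cannot be told apart. Hydrogen in place of bromo gives a number 19 percentage points lower from compound 2 to compound 4 (beyond the scatter), a modest step in the same direction as the large one with chloro, a number 50 percentage points lower from compound 1 to compound 3 (beyond the scatter), so both halogen-bearing compounds read higher than their hydrogen partners, with no listed pair going against this. Nothing shown explains why either halogen step occurs.

Chloro and bromo sit with different groups on the oxygen, so compound 1 and compound 2 cannot show which halogen gives the larger response. Also open, from the compounds shown here alone, is how fluoro or nitrile at that aromatic carbon, or a longer chain such as propoxy on the ring, would read in this assay.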